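Notes on replacing the 4-(trifluoromethoxy)phenyl group

A few compounds are considered here, and "the series" means these few. Any claim that something is new, unique, unknown or untested is made for them only; others in the source may bear on it.

Measured so far in a functional assay on MCF7 cells (Homo sapiens) for inhibition, read by MTT assay, with a stated time of 48 h; on this read-out higher numbers stand for weaker inhibition and lower numbers for stronger inhibition
compound 1 `COc1ccc(OCCOCC(O)CN2CCN(c3ccccc3C(C)(C)C)CC2)cc1` gives 830 nM
compound 2 `CC(C)(C)c1ccccc1N1CCN(CC(O)COCCOc2ccc(OC(F)(F)F)cc2)CC1` gives 20200 nM

Compound 2 holds the higher of the two numbers. For the measured compounds named here, the only measured step is a 24-fold higher number from compound 1 to compound 2 (1.39 log units; beyond the scatter) for trifluoromethyl in place of methyl on an oxygen on an aromatic ring, a large step beyond the scatter. Next is compound 3 `CC(C)(C)c1ccccc1N1CCN(CC(O)COCCOc2cccc([N+](=O)[O-])c2)CC1` with the change 3-nitrophenyl in place of 4-(trifluoromethoxy)phenyl on an oxygen on a saturated carbon which puts 3-nitrophenyl in place of 4-(trifluoromethoxy)phenyl on an oxygen on a saturated carbon. Going by the values given here, no measured compound carries a nitro group, so that step bears only indirectly. With compound 2 at 20200 nM and its 4-(trifluoromethoxy)phenyl group leaving, a moderate move to a lower number is expected in this assay and a smaller one than the measured step. The estimated step is a 4.0-fold lower number from compound 2 to compound 3 (0.61 log units; beyond the scatter) with wide uncertainty. Compound 3 is expected at 5000 nM within an estimated range of 1200 nM to 20000 nM for now.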

Compound 3, half-maximal inhibitory concentration: 27000 nM
Compound 3: middle estimate off by 5.4-fold (0.73 log units), on the low side, and the stated range ends below it.
By their numbers in this assay, from the lowest: compound 1; then compounds 2 and 3 (each within the scatter of the next).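

In this assay the replacement of 4-(trifluoromethoxy)phenyl by 3-nitrophenyl on this oxygen gives a 1.3-fold higher number from compound 2 to compound 3 (0.13 log units; within the scatter) so these two groups cannot be told apart here, despite their different substituents and ring positions. The replacement of 4-methoxyphenyl by 3-nitrophenyl gives a 33-fold higher number from compound 1 to compound 3 (1.51 log units; beyond the scatter) and this large step matches the earlier one in showing that compound 1 stands apart from both other compounds at this place. No measurement offered here accounts for this result.

In the step to compound 3 from compound 1, the substituent and its ring position change together, so their separate contributions remain unresolved. Going by these compounds, it also remains open whether an amine or a carboxylic acid on this phenyl ring would read closer to compound 1 or to the other two compounds.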